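The compounds below may be only part of what the source reports. "The series", "measured", "known", "first", "only" and "open" are said of these compounds alone.

Compound 1 `O=C(NS(=O)(=O)c1ccc(F)cc1)c1ccc(Nc2nc(NC3(c4ccc(Cl)cc4)CC3)nc(OCC(F)(F)F)n2)cc1` — 100%
Compound 2 `CC(C)(C)OC(=O)NCCS(=O)(=O)NC(=O)c1ccc(Nc2nc(NC3(c4ccc(Cl)cc4)CC3)nc(OCC(F)(F)F)n2)cc1` — 92%
Compound 3 `O=C(NS(=O)(=O)CCNC(=O)C1CC1)c1ccc(Nc2nc(NC3(c4ccc(Cl)cc4)CC3)nc(OCC(F)(F)F)n2)cc1` — 90%

Of the compounds shown here, three sharing one core have been measured in an ADME assay on microsomes from liver (Homo sapiens) for metabolic stability, with a stated time of 10 min; a higher number here means that more of the compound is left, a lower number that less of the compound is left. Compound 1 gives 100% in this assay, compound 2 gives 92%, and compound 3 gives 90%. Compound 3 sits at the lower edge of these three numbers, yet every gap is small: the step of a number 2 percentage points lower from compound 2 to compound 3 (within the scatter) and the step of a number 10 percentage points lower from compound 1 to compound 3 (within the scatter) both stay inside the scatter, so no ranking among the three can be read from them.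

Compound 4 `O=C(NS(=O)(=O)C1CC1)c1ccc(Nc2nc(NC3(c4ccc(Cl)cc4)CC3)nc(OCC(F)(F)F)n2)cc1` differs from compound 3 at the sulfonyl sulfur: cyclopropyl in place of 2-((cyclopropylcarbonyl)amino)ethyl on a sulfonyl sulfur. The measured steps that bear on this change all touch the same position. The step of a number 8 percentage points lower from compound 1 to compound 2 (within the scatter) and the step of a number 10 percentage points lower from compound 1 to compound 3 (within the scatter) exchange the group on the sulfonyl sulfur, and the step of a number 2 percentage points lower from compound 2 to compound 3 (within the scatter) alters the chain that compound 4 now loses; none of them moves this assay beyond the scatter. The account therefore expects no step beyond the scatter in this assay, with the change a number 2 percentage points higher from compound 3 to compound 4 (within the scatter) estimated as essentially flat. Compound 4 is expected to give about 92% in this assay, likely between 80% and 100%.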

Compound 4, percent of the compound remaining: 100%
Beside the measured number, compound 4's estimate is 8 percentage points below it, within the range that was stated.
By their numbers in this assay, from the lowest: compounds 3, 2, 1 and 4 (each within the scatter of the next).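

On a sulfonyl sulfur whose other neighbour is an amide-type nitrogen, cyclopropyl now stands with 4-fluorophenyl and the two amide-bearing ethyl chains as a group that leaves this assay inside the scatter: the read-out shows a number 10 percentage points higher from compound 3 to compound 4 (within the scatter), a number 8 percentage points higher from compound 2 to compound 4 (within the scatter) and no change at the digits printed from compound 1 to compound 4 (within the scatter). The step to compound 4 replaces 2-((cyclopropylcarbonyl)amino)ethyl with a three-membered ring of carbon only, dropping the hydrogen-bond donor, the hydrogen-bond acceptor and the double bond that the chain carries, and even this cut does not take the number beyond the scatter. No measurement shown offers a reason for these numbers.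

As far as these compounds go, with all four compounds within the scatter of one another, this assay gives no ranking of the groups at this position, and it remains open whether any group placed there would move the number beyond the scatter. An amine or a carboxylic acid at the end of the ethyl chain, or a longer chain on the sulfonyl sulfur, would test that question, and nothing shown here says how such groups would behave.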